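Methyl Added Beside a Methoxy Group: Acid Dissociation Unchanged

The source may hold more compounds than are shown below. What is called first, only, known or untested is meant among the compounds shown, and "the series" means these compounds.

Compound 1 `COc1cnc(C[S+]([O-])c2nc3cc(OC(F)F)ccc3[nH]2)cc1OC` and compound 2 `COc1cnc(C[S+]([O-])c2nc3cc(OC(F)F)ccc3[nH]2)c(C)c1OC` share one core, while compound 3 `COc1ccnc(C[S+]([O-])c2nc3cc(OC(F)(F)C(F)F)ccc3[nH]2)c1` and compound 4 `COc1cc(C[S+]([O-])c2nc3cc(OC(F)(F)C(F)F)ccc3[nH]2)ncc1C` share another; the difference between the two cores is not broken down here. Compound 1 and compound 2 differ only in methyl in place of hydrogen on an aromatic carbon. In a physicochemical assay for acid dissociation, compound 1 gives 3.75, and compound 2 gives 3.73, so the change produced a number 0.02 log units lower from compound 1 to compound 2 (within the scatter). Compound 3, measured in this assay, gives 4.25, the highest of the three numbers and beyond the scatter from both compound 1 and compound 2.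

Compound 4 arises from compound 3 by methyl in place of hydrogen on an aromatic carbon. This is the same kind of change as from compound 1 to compound 2, but the surroundings differ: in compound 2 the methyl sits ortho to a large group and meta to a methoxy group, whereas in compound 4 it sits para to a large group. Since the earlier change left the proton's readiness to dissociate unchanged within the scatter, the expectation is that compound 4 will behave like compound 3 in this assay, with an expected step of a number 0.02 log units lower from compound 3 to compound 4 (within the scatter). The estimated value for compound 4 in this assay is therefore 4.23, likely falling between 3.9 and 4.55.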

Compound 4, acid dissociation constant: 4.95
For compound 4 the middle estimate is 0.72 log units below the measured one; the whole stated range lies below it.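

In this assay, the change from 4-methoxypyridin-2-yl to 4-methoxy-5-methylpyridin-2-yl gives a number 0.70 log units higher from compound 3 to compound 4 (beyond the scatter), whereas methyl in place of hydrogen on the other core gave a number 0.02 log units lower from compound 1 to compound 2 (within the scatter), so a step that lay within the scatter in one setting did not carry over to the other. Within the data shown here, this does not show that the core alone decides the size of the step: each core supplies only one pair, and the methyl also stands in different surroundings in the two pairs, so the core and the place of the methyl cannot be separated here. The compounds shown offer no measurement that bears on why the two steps differ.

The compounds shown leave open whether another group on the same aromatic carbon, such as an ethyl group, a chlorine atom or an amine, would give a step like the one from methyl. They also leave open whether methyl would give a similar step on the core of compound 1 if it stood para to the large group, as it does in compound 4.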